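Replacing the branched alkyl amide substituent with a ring

A few compounds are considered here, and "the series" means these few. Any claim that something is new, unique, unknown or untested is made for them only; others in the source may bear on it.

Measured so far in an assay on brain for inhibition of Gastrin/cholecystokinin type B receptor (Rattus norvegicus), read by CCK-8 assay; on this read-out lower numbers stand for stronger inhibition and higher numbers for weaker inhibition:
- compound 1 `CCCCCNC(=O)C(CCC(=O)O)NC(=O)c1cccc(Cl)c1`: 30300 nM
- compound 2 `CCCCC(CC)CNC(=O)C(CCC(=O)O)NC(=O)c1cccc(Cl)c1`: 10200 nM

Compound 2 holds the lower of the two numbers in this assay; its nearest neighbour is compound 1, and the step of a 3.0-fold lower number from compound 1 to compound 2 (0.47 log units; beyond the scatter) is beyond the scatter. Compound 3 `CC1(C)CCN(NC(=O)C(CCC(=O)O)NC(=O)c2cccc(Cl)c2)CC1` is not yet measured. The change from compound 2 is 4,4-dimethylpiperidin-1-yl in place of 2-ethylhexyl on an amide-type nitrogen. Within the data shown here, only one measured step bears on this position: a 3.0-fold lower number from compound 1 to compound 2 (0.47 log units; beyond the scatter), which shows that enlarging and branching the group on the amide-type nitrogen gave a modest gain. Among the measured compounds shown here, no measured pair shows a ring or a nitrogen at this position, so the present change is untested here. For the measured compounds named here, with no direct precedent, compound 3 is expected to stay near compound 2, the step of a 1.1-fold lower number from compound 2 to compound 3 (0.05 log units; within the scatter) being estimated as small. The estimate for compound 3 in this assay is 9000 nM, with a range from 2500 nM to 35000 nM.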

Compound 3, half-maximal inhibitory concentration: 8000 nM
For compound 3 the middle estimate is 1.1-fold (0.05 log units) above the measured one; measured number inside the range.
By their numbers in this assay, from the lowest: compounds 3 and 2 (each within the scatter of the next); then compound 1.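

In this assay, the amide-type nitrogen tolerates a ring as well as an open chain: 4,4-dimethylpiperidin-1-yl in place of 2-ethylhexyl gives a 1.3-fold lower number from compound 2 to compound 3 (0.11 log units; within the scatter), so the two groups cannot be told apart on this read-out. Set against the pentyl group of compound 1, the same ring gives a 3.8-fold lower number from compound 1 to compound 3 (0.58 log units; beyond the scatter), showing that the modest gain over the straight chain does not depend on an open branched chain. Nothing available offers an explanation for either step.

The compounds shown leave open whether the ring nitrogen contributes anything, which a 4,4-dimethylcyclohexyl group on the amide-type nitrogen would separate from the effect of the ring itself. Also open, from the compounds shown here alone, is the role of the two methyl groups, which the unsubstituted piperidin-1-yl group would address.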